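Moving the Chlorine Around the Phenyl Ring

The source may report more compounds than this note shows. Statements on the series, on what has been measured and on what is new or still open speak of the compounds shown alone.

Compound 1 `OC(CCn1nc2c(Br)c(Br)c(Br)c(Br)c2n1)c1ccccc1` and compound 2 `OC(CCn1nc2c(Br)c(Br)c(Br)c(Br)c2n1)c1cccc(Cl)c1` share the same core and differ only in a chlorine on the phenyl ring. In a functional assay on MCF7 cells (Homo sapiens) for antiproliferative activity, read by MTT assay, with a stated time of 48 h, tested at 100 uM (a higher number here means a weaker effect of the compound at the concentration tested, a lower number a stronger effect), compound 1 gives 0%, and compound 2 gives 0.5%. Of the two numbers, compound 2 stands highest, yet the step of a number 0.5 percentage points higher from compound 1 to compound 2 (within the scatter) lies within the scatter, so the two readings cannot be told apart. Compound 3 `OC(CCn1nc2c(Br)c(Br)c(Br)c(Br)c2n1)c1ccc(Cl)cc1` has not yet been measured. It differs from compound 2 by 4-chlorophenyl in place of 3-chlorophenyl on a saturated chain carbon bound to an oxygen on a saturated carbon and a saturated chain carbon; the chlorine stays on the same ring but sits at a different spot. Among the compounds with values here, no measured step covers such a relocation. Within the data shown here, the only step known, a number 0.5 percentage points higher from compound 1 to compound 2 (within the scatter), concerns adding the chlorine rather than moving it, and it was small. Among the measured compounds shown here, with both measured compounds sitting at the bottom of the scale and the one change tried leaving the read-out unchanged, the expected step is a number 0.5 percentage points higher from compound 2 to compound 3 (within the scatter), nothing beyond the scatter. Compound 3 is therefore estimated at 1%, with a range from 0% to 12%.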

Compound 3, a percentage reported as activity, at one concentration (the size of the read-out at that concentration, not a potency): 0%
Beside the measured number, compound 3's estimate is 1 percentage points above it; low and high end bracket the measured number.
By their numbers in this assay, from the lowest: compounds 1, 3 and 2 (each within the scatter of the next).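

In this assay, exchanging 3-chlorophenyl for 4-chlorophenyl on the saturated chain carbon gives a number 0.5 percentage points lower from compound 2 to compound 3 (within the scatter). Within the data shown here, this is the first reading on relocating the chlorine rather than adding it, and it shows that this relocation, with the same atoms joined differently, does not separate the two compounds. Chloro in place of hydrogen on an aromatic carbon, now in the arrangement of 4-chlorophenyl, gives no change at the digits printed from compound 1 to compound 3 (within the scatter), so the plain phenyl ring and both chlorophenyl groups shown cannot be told apart at this one test concentration, and nothing measured on these compounds speaks to why the readings lie so close together.

As far as these compounds go, a reading at one concentration is not a potency, so any differences among the three compounds that might appear at lower concentrations remain unknown. From the compounds shown here alone, it also remains open whether a larger change at this position, such as an amine or a carboxylic acid on the phenyl ring, or a longer chain joining that ring to the shared core, would move the number beyond the usual scatter.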